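Replacing a side chain of compound 3 with phenyl

The source may report more compounds than this note shows. Statements on the series, on what has been measured and on what is new or still open speak of the compounds shown alone.

In a functional assay on HEL cells (Homo sapiens) (a higher number here means that more compound is tolerated, a lower number that less compound is tolerated), compound 1 `CCOC(=O)CNC(=O)NC1=CS(=O)(=O)O[C@@]12[C@@H](CO[Si](C)(C)C(C)(C)C)O[C@@H](n1cc(C)c(=O)n(C)c1=O)[C@@H]2O[Si](C)(C)C(C)(C)C` gives 13000 nM and compound 2 `Cc1cn([C@@H]2O[C@H](CO[Si](C)(C)C(C)(C)C)[C@@]3(OS(=O)(=O)C=C3NC(N)=O)[C@H]2O[Si](C)(C)C(C)(C)C)c(=O)n(C)c1=O` gives 11000 nM while compound 3 `COC(=O)CC(=O)NC1=CS(=O)(=O)O[C@@]12[C@@H](CO[Si](C)(C)C(C)(C)C)O[C@@H](n1cc(C)c(=O)n(C)c1=O)[C@@H]2O[Si](C)(C)C(C)(C)C` stands highest of the three at 29000 nM on these numbers. Compound 4 `Cc1cn([C@@H]2O[C@H](CO[Si](C)(C)C(C)(C)C)[C@@]3(OS(=O)(=O)C=C3NC(=O)c3ccccc3)[C@H]2O[Si](C)(C)C(C)(C)C)c(=O)n(C)c1=O` is still unmeasured and carries phenyl in place of (methoxycarbonyl)methyl on a carbonyl carbon. Going by the values given here, no measured compound carries this phenyl, so the closest guides are two changes on that same carbonyl carbon: a 2.2-fold higher number from compound 1 to compound 3 (0.35 log units; beyond the scatter) and a 2.6-fold higher number from compound 2 to compound 3 (0.42 log units; beyond the scatter) are both modest. Once that group is gone, a modest fall in this assay is expected rather than a large one. The expected step is a 2.1-fold lower number from compound 3 to compound 4 (0.32 log units; beyond the scatter) in size. For compound 4 the estimated value is 14000 nM (6000 nM to 32000 nM).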

Compound 4, half-maximal cytotoxic concentration: 9700 nM
The estimate for compound 4 lay 1.4-fold (0.16 log units) above the measured number; the range from low to high includes it.
By their numbers in this assay, from the lowest: compounds 4, 2 and 1 (each within the scatter of the next); then compound 3.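

In this assay phenyl on this carbonyl carbon gives a 3.0-fold lower number from compound 3 to compound 4 (0.48 log units; beyond the scatter) and does not keep the higher number of compound 3. The other two comparisons, a 1.1-fold lower number from compound 2 to compound 4 (0.05 log units; within the scatter) and a 1.3-fold lower number from compound 1 to compound 4 (0.13 log units; within the scatter), are within the scatter, so among these four compounds only the (methoxycarbonyl)methyl of compound 3 stands apart. No evidence here explains this difference.

From the compounds shown here alone, it remains open whether the methoxycarbonyl end or the chain itself matters for compound 3. A carboxylic acid or a longer chain on this carbonyl carbon would help separate these.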